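The source may hold more compounds than are shown below. What is called first, only, known or untested is meant among the compounds shown, and "the series" means these compounds.

Compound 3 `COc1ccc(Cn2nc(-c3ccccc3)c3cc(C(=N)Nc4ccccc4)nc(NC4CCCCC4)c32)cc1` and compound 1 `N=C(Nc1ccccc1)c1cc2c(-c3ccccc3)n[nH]c2c(NC2CCCCC2)n1` share one core and differ only in hydrogen in place of 4-methoxybenzyl on an aromatic nitrogen. In a functional assay on PC-3 cells (Homo sapiens) for cytotoxicity, read by MTT assay, with a stated time of 72 h (a lower number here means a stronger inhibitor, a higher number a weaker inhibitor), compound 3 gives 1100 nM, and compound 1 gives 1730 nM. The step of a 1.6-fold higher number from compound 3 to compound 1 (0.20 log units; within the scatter) thus leaves the two compounds within the scatter of one another, so nothing can be said about an order between them. Compound 2 `COc1ccc(Cn2nc(-c3ccccc3)c3cc(C(=N)Nc4cccc(C(F)(F)F)c4)nc(Nc4cc(OC)c(OC)c(OC)c4)c32)cc1` carries the same 4-methoxybenzyl group on its core, but how that core differs from the core of compound 3 is not broken down here. For compound 2 the outcome in this assay is "not determined" (no result reported). Among the compounds with values here, compound 4 `COc1cc(Nc2nc(C(=N)Nc3cccc(C(F)(F)F)c3)cc3c(-c4ccccc4)n[nH]c23)cc(OC)c1OC` is related to compound 2 by hydrogen in place of 4-methoxybenzyl on an aromatic nitrogen, which is the same change, at the same place, as the one from compound 3 to compound 1. Because a 1.6-fold higher number from compound 3 to compound 1 (0.20 log units; within the scatter) stayed within the scatter, the same change is expected to do little from compound 2 to compound 4, though with no number for compound 2 this rests only on compound 1 and compound 3. Compound 4 is therefore estimated to come in near 900 nM, between 200 nM and 5000 nM.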

Compound 4, half-maximal inhibitory concentration: 13900 nM
For compound 4 the middle estimate is 15-fold (1.19 log units) below the measured one; the whole stated range lies below it.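

Within the data shown here, no step from compound 2 to compound 4 can be read in this assay, as compound 2 has no number there. The compounds shown leave open whether hydrogen in place of 4-methoxybenzyl has the same outcome in this pair as in compound 3 and compound 1. No evidence shown here bears on the value of compound 4.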